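The compounds below may be only part of what the source reports. "The series", "measured", "known", "first", "only" and "open" are said of these compounds alone.

For the measured compounds named here, in a functional assay on HCT-8 cells (Homo sapiens) for cytotoxicity (a lower number here means that less compound is needed, a higher number that more compound is needed for the effect), compound 3 (`COC1=C(C)C(=O)/C(=C(O)/C=C/c2cccs2)C(=O)C1(C)C`) stands at 8.6 ug/mL and has the highest number of the three measured so far. Compound 1 (`COC1=C(C)C(=O)/C(=C(O)/C=C/c2cccc(OC)c2)C(=O)C1(C)C`) at 2.9 ug/mL and compound 2 (`COC1=C(C)C(=O)/C(=C(O)/C=C/c2ccc(F)cc2)C(=O)C1(C)C`) at 3.6 ug/mL lie within the scatter of each other (a 1.2-fold higher number from compound 1 to compound 2 (0.09 log units; within the scatter)). Compound 4 (`COC1=C(C)C(=O)/C(=C(O)/C=C/c2nccs2)C(=O)C1(C)C`) carries one change (1,3-thiazol-2-yl in place of thiophen-2-yl on a double-bonded chain carbon bound to a double-bonded chain carbon) on a double-bonded chain carbon bound to a double-bonded chain carbon. Going by the values given here, no measured step makes this exact exchange. The closest evidence is at the same place, where two modest steps (a 3.0-fold higher number from compound 1 to compound 3 (0.47 log units; beyond the scatter) and a 2.4-fold higher number from compound 2 to compound 3 (0.38 log units; beyond the scatter)) each lead to thiophen-2-yl from a substituted phenyl. With one five-membered aromatic ring exchanged for another, the expected step (a 1.1-fold lower number from compound 3 to compound 4 (0.03 log units; within the scatter)) stays within the scatter, in neither direction. For compound 4 the estimated value is 8 ug/mL (from 3.5 ug/mL to 19 ug/mL).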

Compound 4, concentration for half-maximal effect: 5.1 ug/mL
Beside the measured number, compound 4's estimate is 1.6-fold (0.20 log units) above it, and the stated range covers the measured number.
By their numbers in this assay, from the lowest: compounds 1, 2, 4 and 3 (each within the scatter of the next, the first and the last beyond it).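

At the place on a double-bonded chain carbon bound to a double-bonded chain carbon, in this assay, 1,3-thiazol-2-yl in place of thiophen-2-yl stays within the scatter (a 1.7-fold lower number from compound 3 to compound 4 (0.23 log units; within the scatter)). Compound 4 also stays within the scatter of both substituted phenyl compounds (a 1.4-fold higher number from compound 2 to compound 4 (0.15 log units; within the scatter); a 1.8-fold higher number from compound 1 to compound 4 (0.25 log units; within the scatter)), unlike compound 3. No measurement at hand accounts for these steps. As far as these compounds go, whether a pyridin-2-yl group or a carboxylic acid at this place would stay in the same range remains open, as does any change to the shared core.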